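Swapping a para fluoro for methoxy in a pyrazoline series

The compounds below may be only part of what the source reports. "The series", "measured", "known", "first", "only" and "open" are said of these compounds alone.

Measured compounds:
compound 1 `Cc1ccc(C2=NN(C3=NC(c4ccccc4)CS3)C(c3ccc4ccccc4c3)C2)cc1` 14700 nM
compound 2 `Fc1ccc(C2=NN(C3=NC(c4ccccc4)CS3)C(c3ccc4ccccc4c3)C2)cc1` 26500 nM

In a functional assay on HepG2 cells (Homo sapiens) for inhibition, read by CCK-8 assay, with a stated time of 48 h (on this read-out lower numbers stand for stronger inhibition and higher numbers for weaker inhibition), compound 2 gives 26500 nM. Of the two numbers, compound 2 sits beside compound 1, separated only by a 1.8-fold higher number from compound 1 to compound 2 (0.26 log units; within the scatter). Compound 3 `COc1ccc(C2=NN(C3=NC(c4ccccc4)CS3)C(c3ccc4ccccc4c3)C2)cc1` differs from compound 2 by methoxy in place of fluoro on an aromatic carbon. Within the data shown here, no measured step covers methoxy at this position; the sole step, methyl to fluoro, stayed within the scatter. Compound 3 is therefore expected near compound 2 in this assay, with a 1.3-fold lower number from compound 2 to compound 3 (0.12 log units; within the scatter) as the estimated step. The estimated value for compound 3 is 20000 nM, within 8000 nM to 50000 nM.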

Compound 3, half-maximal inhibitory concentration: 12600 nM
For compound 3 the middle estimate is 1.6-fold (0.20 log units) above the measured one, within the range that was stated.
By their numbers in this assay, from the lowest: compounds 3, 1 and 2 (each within the scatter of the next, the first and the last beyond it).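

In this assay, this position now shows a change that clears the scatter: 4-fluorophenyl to 4-methoxyphenyl gives a 2.1-fold lower number from compound 2 to compound 3 (0.32 log units; beyond the scatter) in this series. Methoxy and methyl, by contrast, cannot be told apart here, with a 1.2-fold lower number from compound 1 to compound 3 (0.07 log units; within the scatter) on swapping one for the other. Nothing available explains why methoxy and fluoro differ. Still open, going by these compounds, is how an amine, a carboxylic acid or a longer chain such as ethoxy would read at this position, and whether any group placed here could bring the number far lower.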